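The source may report more compounds than this note shows. Statements on the series, on what has been measured and on what is new or still open speak of the compounds shown alone.

Going by the values given here, in a functional assay with Homo sapiens as the target (a higher number here means a weaker inhibitor, a lower number a stronger inhibitor), three compounds built on one shared core have numbers so far. Compound 1 `CC(C)[C@H](NC(=O)COc1cccc2ccccc12)C(=O)N[C@@H](CC(=O)O)C(=O)COc1cccc2ccccc12` gives 19000 nM, compound 2 `CC(C)[C@H](NC(=O)COc1cccc2ccccc12)C(=O)N[C@@H](CC(=O)O)C(=O)COc1ccc(C#N)cc1` gives 26700 nM, and compound 3 `CC(C)[C@H](NC(=O)COc1cccc2ccccc12)C(=O)N[C@@H](CC(=O)O)C(=O)COc1ccccc1[N+](=O)[O-]` gives 27700 nM. Compound 3 thus stands level with the other two, with every gap inside the usual scatter of repeat measurements.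

The next compound is compound 4 `CC(C)[C@H](NC(=O)COc1cccc2ccccc12)C(=O)N[C@@H](CC(=O)O)C(=O)COc1cccc(F)c1`. Its difference from compound 3 is 3-fluorophenyl in place of 2-nitrophenyl on an oxygen on a saturated carbon, which means 3-fluorophenyl in place of 2-nitrophenyl on an oxygen on a saturated carbon.

Three measured steps exchange the group at this same place: a 1.4-fold higher number from compound 1 to compound 2 (0.15 log units; within the scatter), a 1.5-fold higher number from compound 1 to compound 3 (0.16 log units; within the scatter) and a 1.0-fold higher number from compound 2 to compound 3 (0.02 log units; within the scatter). All three stay within the scatter, even with naphthalen-1-yl, 4-cyanophenyl and 2-nitrophenyl swapped for one another. Among the compounds with values here, none of the measured compounds carries 3-fluorophenyl, so this remains an extrapolation from only three compounds.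

On that basis, no step beyond the scatter is expected in this assay, and the expected step is a 1.2-fold lower number from compound 3 to compound 4 (0.06 log units; within the scatter). The estimate for compound 4 is 24000 nM, with an expected range from 12000 nM to 48000 nM.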

Compound 4, half-maximal inhibitory concentration: 12000 nM
Compound 4: middle estimate off by 2.0-fold (0.30 log units), on the high side; measured number inside the range.
By their numbers in this assay, from the lowest: compounds 4, 1, 2 and 3 (each within the scatter of the next, the first and the last beyond it).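

In this assay, going by these compounds alone, the groups on this oxygen no longer look interchangeable: a 2.3-fold lower number from compound 3 to compound 4 (0.36 log units; beyond the scatter) and a 2.2-fold lower number from compound 2 to compound 4 (0.35 log units; beyond the scatter) are modest steps, yet they are the first at this place to lie beyond the scatter. Against naphthalen-1-yl, however, a 1.6-fold lower number from compound 1 to compound 4 (0.20 log units; within the scatter) stays within the scatter, so 3-fluorophenyl stands clear of 2-nitrophenyl and 4-cyanophenyl but not of naphthalen-1-yl. The whole set still spans only a small range, and one fluorine-bearing compound is a thin basis for any trend.

The compounds shown leave open whether a plain phenyl, a chlorophenyl or a pyridine ring at this place would sit with compound 4 or with compound 3. Nothing measured alongside these numbers accounts for the gaps.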